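Thiophen-3-yl in Place of Phenyl: What to Expect

The source may report more compounds than this note shows. Statements on the series, on what has been measured and on what is new or still open speak of the compounds shown alone.

Compound 1 `CCCc1ccc(B2OC(C)(C)C(C)(C)O2)cc1` and compound 2 `CC1(C)OB(c2ccc(-c3ccccc3)cc2)OC1(C)C` share the same core and differ only in the group on its outer aromatic carbon. In an assay on isolated protein for inhibition of endothelial lipase (Homo sapiens), with a stated time of 1 h (on this read-out higher numbers stand for weaker inhibition and lower numbers for stronger inhibition), compound 1 gives 5000 nM. Going by the values given here, compound 2 gives 1000 nM in this assay, the lowest of the two numbers measured so far; its only neighbour is compound 1, and the step between them was a 5.0-fold lower number from compound 1 to compound 2 (0.70 log units; beyond the scatter).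

Compound 3 `CC1(C)OB(c2ccc(-c3ccsc3)cc2)OC1(C)C` continues from compound 2 with a single change: thiophen-3-yl in place of phenyl on an aromatic carbon. Among the compounds with values here, only one measured step exists to lean on, the one from compound 1 to compound 2, and it swapped a propyl chain for a phenyl ring, a different kind of change from exchanging one aromatic ring for another. Within the data shown here, it therefore gives little direct guidance, and there is no measured example of a ring-for-ring swap. The expectation for compound 3 is consequently a step no larger than the scatter, a 1.1-fold lower number from compound 2 to compound 3 (0.05 log units; within the scatter). Compound 3 is therefore estimated at 900 nM, with a range from 300 nM to 3000 nM.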

Compound 3, half-maximal inhibitory concentration: 1300 nM
Beside the measured number, compound 3's estimate is 1.4-fold (0.16 log units) below it; measured number inside the range.
By their numbers in this assay, from the lowest: compounds 2 and 3 (each within the scatter of the next); then compound 1.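

In this assay the ring exchange gives a 1.3-fold higher number from compound 2 to compound 3 (0.11 log units; within the scatter), so on this aromatic carbon, para to a group of 9 heavy atoms, a five-membered aromatic ring with one sulfur atom and a six-membered aromatic ring of carbon only cannot be told apart. Thiophen-3-yl in place of propyl gives a 3.8-fold lower number from compound 1 to compound 3 (0.59 log units; beyond the scatter) and stays beyond the scatter, which shows that the lower number seen against the propyl compound is not confined to phenyl: both aromatic rings shown, in compound 2 and compound 3, share it. Nothing measured here explains why the two rings read alike or why both differ from the propyl chain.

The compounds shown leave open whether an aromatic ring is needed at this carbon at all, a question that a saturated ring such as cyclohexyl or a longer chain such as hexyl would address. Also open, as far as these compounds go, is how a ring containing nitrogen, such as pyridin-3-yl, or a phenyl ring carrying an amine or a carboxylic acid, would read in this assay.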